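This account rests on a few compounds, and the source may have more. Where it says the series, first, only, none or still open, it means among the compounds named here.

Compound 1 `O=c1ccn(CCN2CCCCC2)c(CO)c1O`, compound 2 `Cc1c(O)c(=O)ccn1CCN(C)C` and compound 3 `CC(O)c1c(O)c(=O)ccn1CCN1CCCCC1` have all been measured in a physicochemical assay for acid dissociation, read by spectrophotometry. Compound 1 gives 2.2, compound 2 gives 2.86 and compound 3 gives 2.14. Compound 3 arises from compound 1 by methyl in place of hydrogen on a saturated chain carbon bound to an aromatic carbon and an oxygen on a saturated carbon, a change that made a step of a number 0.06 log units lower from compound 1 to compound 3 (within the scatter). How the core of compound 2 differs from the core of compound 1 is not broken down here; the two values simply show compound 2 standing highest of the three. Compound 4 `CCc1c(O)c(=O)ccn1CCN(C)C` is not yet measured and differs from compound 2 by methyl in place of hydrogen on a saturated chain carbon bound to an aromatic carbon. This is the same kind of change as the earlier one, though the earlier place also carried an oxygen on a saturated carbon. Resting on the earlier step of a number 0.06 log units lower from compound 1 to compound 3 (within the scatter), the expected step is a number 0.06 log units lower from compound 2 to compound 4 (within the scatter). For compound 4 the estimated value is 2.8, likely between 2.5 and 3.1.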

Compound 4, acid dissociation constant: 2.68
Compound 4: middle estimate off by 0.12 log units, on the high side, within the range that was stated.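

The new step in this assay reads a number 0.18 log units lower from compound 2 to compound 4 (within the scatter) and stands alongside a number 0.06 log units lower from compound 1 to compound 3 (within the scatter) on the other core, so for these two pairs, methyl in place of hydrogen leaves the number inside the usual scatter. This does not show that the two steps are truly equal or that the result holds on other cores, and the earlier place also carried an oxygen on a saturated carbon. Nothing available here bears on what lies behind these small steps.

The compounds shown leave open what a longer chain than ethyl would do at this place. An amine or a carboxylic acid on that chain also remains an open case.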